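The source may report more compounds than this note shows. Statements on the series, on what has been measured and on what is new or still open speak of the compounds shown alone.

Compound 1, `O=C1CS/C(=N\c2csc(-c3ccc(Cl)cc3)c2)N1`, in a functional assay on HCT-116 cells (Homo sapiens) for cytotoxicity, read by MTT assay, with a stated time of 72 h (a higher number here means a weaker inhibitor, a lower number a stronger inhibitor), gives only a limit of the assay, > 50000 nM, and no number. For the measured compounds named here, compound 2, `O=C1N/C(=N/c2csc(-c3ccc(Cl)cc3)c2)S/C1=C\c1ccc(Br)cc1`, gives 3300 nM in this assay, and this is the only actual number in the set. Going by the values given here, the one other value shown, that of compound 1, is a limit of the assay. Compound 3, `COc1ccc(/C=C2\S/C(=N\c3csc(-c4ccc(Cl)cc4)c3)NC2=O)cc1OC`, differs from compound 2 by 3,4-dimethoxyphenyl in place of 4-bromophenyl on a double-bonded chain carbon bound to a double-bonded ring carbon. Among the compounds with values here, no measured step of this kind exists here, so the expected change from compound 2 to compound 3 is a 1.2-fold higher number from compound 2 to compound 3 (0.08 log units; within the scatter), a shift not larger than the usual scatter. Compound 3 is accordingly estimated at 4000 nM, with a likely range from 1500 nM to 12000 nM.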

Compound 3, half-maximal inhibitory concentration: 1700 nM
Beside the measured number, compound 3's estimate is 2.4-fold (0.37 log units) above it, within the range that was stated.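

The step of a 1.9-fold lower number from compound 2 to compound 3 (0.29 log units; within the scatter) comes with 3,4-dimethoxyphenyl in place of 4-bromophenyl on a double-bonded chain carbon bound to a double-bonded ring carbon. So in this assay this position takes a larger aromatic group carrying hydrogen-bond acceptors with no change beyond the scatter. Compound 1, which carries neither group, stays at a limit of the assay, not a number: the limit of > 50000 nM in this assay, at which 1 of the 3 values shown sits.

Going by these compounds, whether an amine or a carboxylic acid on this phenyl ring would be tolerated stays open. So does whether a simple methyl group could replace the ring altogether.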